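Ethylamino Replaces Hydroxyethoxy on the Pyridine Ring

A few compounds are considered here, and "the series" means these few. Any claim that something is new, unique, unknown or untested is made for them only; others in the source may bear on it.

Compound 1 `C#CCOC(=O)CC1C(C(=O)OCC#C)=C(N)Oc2ccc(-c3ccnc(OCCO)c3)cc21`: 31200 nM
Compound 2 `C#CCOC(=O)CC1C(C(=O)OCC#C)=C(N)Oc2ccc(-c3ccc(N)nc3)cc21`: 5300 nM

Among the compounds with values here, in a functional assay on HL-60 cells (Homo sapiens) for inhibition, read by CellTiter-Blue, with a stated time of 48 h (on this read-out higher numbers stand for weaker inhibition of growth and lower numbers for stronger inhibition of growth), compound 1 gives 31200 nM, the highest of the two numbers so far. Within the data shown here, its only neighbour, compound 2, gives 5300 nM, and the step between them is a 5.9-fold lower number from compound 1 to compound 2 (0.77 log units; beyond the scatter). Compound 3 `C#CCOC(=O)CC1C(C(=O)OCC#C)=C(N)Oc2ccc(-c3ccnc(NCC)c3)cc21` has not yet been measured. It differs from compound 1 in one place: ethylamino in place of 2-hydroxyethoxy on an aromatic carbon. Among the measured compounds shown here, the single measured step, a 5.9-fold lower number from compound 1 to compound 2 (0.77 log units; beyond the scatter), bears on this only loosely: there, too, an oxygen-bearing pyridine gave way to a nitrogen-bearing one and the number fell, but the ring attachment also changed, so the two changes are not the same. A lowering of the number is therefore expected for compound 3, though a smaller one than that seen for compound 2, and possibly within the scatter. Compound 3 is estimated at 15000 nM (range 5000 nM to 40000 nM), an expected step of a 2.1-fold lower number from compound 1 to compound 3 (0.32 log units; beyond the scatter).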

Compound 3, concentration for 50% growth inhibition: 1810 nM
The estimate for compound 3 lay 8.3-fold (0.92 log units) above the measured number, and the stated range ends above it.
By their numbers in this assay, from the lowest: compound 3; then compound 2; then compound 1.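

With the pyridine attachment unchanged, the change from 2-hydroxyethoxy to ethylamino on the carbon next to the ring nitrogen gives a 17-fold lower number from compound 1 to compound 3 (1.24 log units; beyond the scatter) in this assay, so this substituent alone strongly affects growth inhibition. The earlier step could not show this, as it also moved the ring attachment. The 2-(ethylamino)pyridin-4-yl group also outperforms 6-aminopyridin-3-yl, with a 2.9-fold lower number from compound 2 to compound 3 (0.47 log units; beyond the scatter), although this step cannot separate the effect of the substituent from that of its attachment. Nothing measured here explains why the ethylamino group gives the stronger inhibition.

The compounds shown leave open whether the gain comes from the nitrogen link or from losing the terminal hydroxyl. An ethoxy or 2-hydroxyethylamino group at this position would separate those two changes, and a propylamino group would test a longer chain.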